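Notes on replacing the methoxy group in compound 2

A few compounds are considered here, and "the series" means these few. Any claim that something is new, unique, unknown or untested is made for them only; others in the source may bear on it.

Values so far in a functional assay on MDA-MB-468 cells (Homo sapiens) for antiproliferative activity, read by MTT assay, with a stated time of 48 h; on this read-out lower numbers stand for stronger inhibition and higher numbers for weaker inhibition (compound 3 still open)
- compound 1 `COc1cccc(C(=O)Nc2cc3cnc(NCCN(C)C)cc3n(C)c2=O)c1` gives 17400 nM
- compound 2 `COc1ccc(C(=O)Nc2cc3cnc(NCCN(C)C)cc3n(C)c2=O)cc1` gives 15700 nM
- compound 3 `CN(C)CCNc1cc2c(cn1)cc(NC(=O)c1ccccc1)c(=O)n2C` has not been measured

Compound 2 (15700 nM) and compound 1 (17400 nM) lie within the scatter of each other, so the two numbers cannot be ranked. The next step leads from compound 2 to compound 3, with hydrogen in place of methoxy on an aromatic carbon and the rest of the structure unchanged.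

Among the compounds with values here, only one measured step bears on this change (a 1.1-fold lower number from compound 1 to compound 2 (0.04 log units; within the scatter)). It moves the methoxy group rather than removing it, and its size stays within the scatter. Within the data shown here, no measured compound lacks the methoxy group, so the data do not show directly what its removal does. The position of the group made no visible difference, so a step beyond the scatter is not expected in this assay, and neither direction is favoured.

The expected step is small and within the scatter (a 1.0-fold higher number from compound 2 to compound 3 (0.01 log units; within the scatter)). For compound 3 the estimated value is 16000 nM (expected range 8000 nM to 32000 nM).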

Compound 3, half-maximal inhibitory concentration: 18300 nM
Estimate against measurement, compound 3: 1.1-fold (0.06 log units) below, within the range that was stated.
By their numbers in this assay, from the lowest: compounds 2, 1 and 3 (each within the scatter of the next).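

In this assay, the loss of the methoxy group can now be read directly, and it holds for both placements shown: the change from 4-methoxyphenyl to phenyl gives (a 1.2-fold higher number from compound 2 to compound 3 (0.07 log units; within the scatter)), and the same removal starting from the 3-methoxyphenyl amide gives (a 1.1-fold higher number from compound 1 to compound 3 (0.02 log units; within the scatter)). The earlier step only moved the group, whereas these two steps take out its two heavy atoms and its hydrogen-bond acceptor altogether, and both stay within the scatter, so among these three compounds the methoxy group is not required for the level of the number in this assay. No measurement on hand accounts for this outcome.

Methoxy and hydrogen are the only groups compared on this aromatic ring, so it remains open whether an amine, a carboxylic acid, a chlorine atom or a longer alkoxy chain on the same carbon would give a step beyond the scatter. Going by these compounds, the shared core and the dimethylaminoethyl side chain are the same in all three compounds, so what changes there would do to the number in this assay also remains open.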